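This account rests on a few compounds, and the source may have more. Where it says the series, first, only, none or still open, it means among the compounds named here.

In a functional assay on HepG2 cells (Homo sapiens) for inhibition, read by MTT assay (a lower number here means a stronger inhibitor of growth, a higher number a weaker inhibitor of growth), the measured compounds read:

Compound 1 `COc1cc2oc(-c3cccc(NC(=O)c4ccc(Br)cc4)c3)cc(=O)c2c(OC)c1OC` gives 8850 nM
Compound 2 `COc1cc2oc(-c3cccc(NC(=O)c4ccccc4Br)c3)cc(=O)c2c(OC)c1OC` gives 23100 nM
Compound 3 `COc1cc2oc(-c3cccc(NC(=O)c4ccc([N+](=O)[O-])cc4)c3)cc(=O)c2c(OC)c1OC` gives 18800 nM

Compound 2 stands at the weak end of this small set (a 2.6-fold higher number from compound 1 to compound 2 (0.42 log units; beyond the scatter)) and has no real gap to its nearest neighbour (a 1.2-fold lower number from compound 2 to compound 3 (0.09 log units; within the scatter)). Compound 4 `COc1cc2oc(-c3cccc(NC(=O)c4ccc(C)cc4)c3)cc(=O)c2c(OC)c1OC` has 4-methylphenyl in place of 2-bromophenyl on a carbonyl carbon. The closest guide is compound 1, where 2-bromophenyl in place of 4-bromophenyl brought a modest rise (a 2.6-fold higher number from compound 1 to compound 2 (0.42 log units; beyond the scatter)). Nitro in place of bromo moved the number by a similar size (a 2.1-fold higher number from compound 1 to compound 3 (0.33 log units; beyond the scatter)), and no measured compound carries methyl. In this assay the expected step is therefore a modest fall (a 1.9-fold lower number from compound 2 to compound 4 (0.28 log units; within the scatter)). For compound 4 the estimated value is 12000 nM (expected range 6000 nM to 24000 nM).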

Compound 4, concentration for 50% growth inhibition: 9750 nM
Compound 4: middle estimate off by 1.2-fold (0.09 log units), on the high side, and the stated range covers the measured number.
By their numbers in this assay, from the lowest: compounds 1, 4, 3 and 2 (each within the scatter of the next, the first and the last beyond it).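

In this assay, the step to 4-methylphenyl on this carbonyl carbon gives a 2.4-fold lower number from compound 2 to compound 4 (0.37 log units; beyond the scatter), so moving away from 2-bromophenyl does not require a bromine in the new group. Methyl in place of bromo gives a 1.1-fold higher number from compound 1 to compound 4 (0.04 log units; within the scatter), which leaves 4-methylphenyl and 4-bromophenyl indistinguishable here. Methyl in place of nitro gives a 1.9-fold lower number from compound 3 to compound 4 (0.29 log units; within the scatter), so this pair is not separated either.

No measurement shown explains these steps. From the compounds shown here alone, whether an amine or a carboxylic acid in place of the methyl would keep this growth inhibition remains open.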